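Dimethylamino removal on the propyl chain of compound 1

The source may report more compounds than this note shows. Statements on the series, on what has been measured and on what is new or still open speak of the compounds shown alone.

Among the compounds with values here, compound 1 `CN(C)CCCNc1nc(NCc2ccc(NC(=O)c3ccc(F)cc3)cc2)c2ccccc2n1` is the only member of this set with a number in a functional assay on SW480 cells (Homo sapiens) for inhibition, read by luminescence and resazurin assay, with a stated time of 3 days; a lower number here means a stronger inhibitor, a higher number a weaker inhibitor: compound 1 gives 14000 nM. Compound 2 `CCCNc1nc2ccccc2c(NCc2ccc(NC(=O)c3ccc(F)cc3)cc2)c1C#N` reaches only a limit in this assay; compound 2 gives > 20000 nM, which is a limit of the assay and not a number. Compound 3 `CNc1nc(NCc2ccc(NC(=O)c3ccncc3)cc2)c2ccccc2n1` likewise stops at a limit; in this assay compound 3 gives > 20000 nM, again a limit. Within the data shown here, two of the three values therefore sit at the limit of > 20000 nM in this assay, at which 2 of the 3 values shown sit, and compound 1 stands as the single measured number, itself a weak inhibitor.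

Compound 4 `CCCNc1nc(NCc2ccc(NC(=O)c3ccc(F)cc3)cc2)c2ccccc2n1` is not yet measured. It differs from compound 1 by hydrogen in place of dimethylamino on a saturated chain carbon, three bonds along the chain from a nitrogen on an aromatic ring. Among the measured compounds shown here, no step between measured compounds involves this change, so no measured guide exists for its size or direction. With compound 1 already weak in this assay, a step beyond the scatter would be hard to resolve, and the expectation is a small move toward weaker inhibition, no larger than the scatter, with a fair chance that only a limit is reported. Compound 4 is estimated at 20000 nM, within 9000 nM to 45000 nM, which corresponds to an expected step of a 1.4-fold higher number from compound 1 to compound 4 (0.15 log units; within the scatter).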

Compound 4, half-maximal inhibitory concentration: 2000 nM
Compound 4: the middle estimate sits 10-fold (1.00 log units) above what was measured, and the stated range ends above it.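

In this assay, within the data shown here, hydrogen in place of dimethylamino on the saturated chain carbon gives the first step that can be read (a 7.0-fold lower number from compound 1 to compound 4 (0.85 log units; beyond the scatter)). This position is therefore sensitive to the change, and the dimethylamino group is not needed for inhibition in these cells, since compound 4 carries a plain propyl chain and is the stronger of the pair. That step also gives the series a second number to work from, and further changes to the propyl chain of compound 4 have room to be read in either direction, whereas the other values shown are limits and not numbers: the limit of > 20000 nM in this assay, at which 2 of the 4 values shown sit.

A single step cannot separate the effect of removing the amine from any other feature of the 3-(dimethylamino)propyl to propyl change, so the reason for the shift stays open. As far as these compounds go, a hydroxyl or a primary amine at the end of the propyl chain, or a longer chain such as butyl or pentyl, would show whether the trend continues or depends on the terminal group, and whether it holds in other amides on the shared core also remains untested by these compounds.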